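The source may hold more compounds than are shown below. What is called first, only, known or untested is meant among the compounds shown, and "the series" means these compounds.

Compound 3, with the structure `CCOC(=O)c1c(Nc2ccc(I)cc2F)sc2c1CC(C)(C)CNC2=O`, carries an ethoxy group on a carbonyl carbon attached to the shared core. In a functional assay on HT-29 cells (Homo sapiens) for antiproliferative activity (on this read-out lower numbers stand for stronger inhibition and higher numbers for weaker inhibition), compound 3 gives "not determined" (no result reported), so no number at all is available for it. The neighbouring compounds give some orientation. Compound 1, with the structure `CC1(C)CNC(=O)c2sc(Nc3ccc(I)cc3Cl)c(C(=O)NCC[C@@H](O)CO)c2C1`, shows in this assay a value of 12100 nM. Compound 2, with the structure `CC1(C)CNC(=O)c2sc(Nc3ccc(I)cc3F)nc2C1`, shows in this assay a value of 8870 nM. These two numbers lie close to one another, and both point to weak inhibition of cell growth.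

Compound 4, with the structure `CC1(C)CNC(=O)c2sc(Nc3ccc(I)cc3F)c(C(=O)NOCCO)c2C1`, differs from compound 3 by one change: (2-hydroxyethoxy)amino in place of ethoxy on a carbonyl carbon. As far as these compounds go, since compound 3 itself has no measured number, no step can be read from the data, and the expected direction and size of the change in this assay remain open. Judged only from compound 1 and compound 2, compound 4 is expected to land in the same weak range, with an estimated value of 10000 nM, likely between 3000 nM and 30000 nM.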

Compound 4, half-maximal inhibitory concentration: 340 nM
The estimate for compound 4 lay 29-fold (1.47 log units) above the measured number; measured number outside the range, below it.
By their numbers in this assay, from the lowest: compound 4; then compounds 2 and 1 (each within the scatter of the next).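

No step can be read from compound 3 to compound 4, as compound 3 carries no number in this assay and only compound 4 does. As far as these compounds go, what swapping ethoxy for (2-hydroxyethoxy)amino does to this read-out stays open, and no supporting data bear on the result.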